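The source may hold more compounds than are shown below. What is called first, only, known or untested is meant among the compounds shown, and "the series" means these compounds.

Compound 3 `CCc1cccc(C)c1-n1nncc1CN1C(=O)C2(C(C#N)=C(N)Oc3c(N)cc4nc5ccccc5nc4c32)c2ccccc21` stands only at a limit in a functional assay on MCF7 cells (Homo sapiens) for antiproliferative activity, read by MTT assay, with a stated time of 48 h; on this read-out lower numbers stand for stronger inhibition and higher numbers for weaker inhibition; in this assay compound 3 gives > 50000 nM, a limit rather than a number. Compound 1 `Cc1cccc(-n2nncc2CN2C(=O)C3(C(C#N)=C(N)Oc4c(N)cc5nc6ccccc6nc5c43)c3ccccc32)c1` gives > 50000 nM in this assay, also a limit. Compound 2 `N#CC1=C(N)Oc2c(N)cc3nc4ccccc4nc3c2C12C(=O)N(Cc1cnnn1-c1cccc(Br)c1)c1ccccc12` gives > 50000 nM in this assay, again a limit. The three values share (the limit of > 50000 nM in this assay, at which 3 of the 3 values shown sit), so the steps a step that the two limits leave unreadable from compound 1 to compound 2, a step that the two limits leave unreadable from compound 1 to compound 3 and a step that the two limits leave unreadable from compound 2 to compound 3 cannot be read in size or direction. Compound 4 `N#CC1=C(N)Oc2c(N)cc3nc4ccccc4nc3c2C12C(=O)N(Cc1cnnn1-c1cc(Cl)ccc1Cl)c1ccccc12` carries 2,5-dichlorophenyl in place of 2-ethyl-6-methylphenyl on an aromatic nitrogen. For the measured compounds named here, no measured step resolves a change of this kind, so the step that the limit leaves unreadable from compound 3 to compound 4 is expected to stay within the scatter. Compound 4 is therefore expected near 60000 nM, between 20000 nM and 200000 nM, most likely reported once more as a limit.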

Compound 4, half-maximal inhibitory concentration: 33200 nM
Estimate against measurement, compound 4: 1.8-fold (0.26 log units) above; the measured number falls inside the stated range.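

For the compounds shown here, with 2,5-dichlorophenyl on the aromatic nitrogen, compound 4 gives the one number rather than a limit in this assay, and the other compounds stay at the limit: the limit of > 50000 nM in this assay, at which 3 of the 4 values shown sit. The change reads as an at least 1.5-fold lower number from compound 3 to compound 4 (0.17 log units; that floor lies within the scatter) and as an at least 1.5-fold lower number from compound 2 to compound 4 (0.17 log units; that floor lies within the scatter) and as an at least 1.5-fold lower number from compound 1 to compound 4 (0.17 log units; that floor lies within the scatter) so this position can reach a measurable number, though no step is shown beyond the scatter. The steps among compounds 1, 2 and 3 cannot be read.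

Still open, from the compounds shown here alone, is whether any group at this position moves the number beyond the scatter, and what an amine or a carboxylic acid on this phenyl ring would do.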